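Moving One Methoxy Group on a Phenyl Ring

A few compounds are considered here, and "the series" means these few. Any claim that something is new, unique, unknown or untested is made for them only; others in the source may bear on it.

Three related compounds have been tested so far in an ADME assay on HEK-293T cells (Homo sapiens) for inhibition, read by CCK-8 assay, with a stated time of 48 h, tested at 20 uM (a lower number here means less inhibition of growth, a higher number more inhibition of growth at the concentration tested), and two of them gave numbers. There compound 1 (`COc1ccc(S(=O)(=O)Oc2ccccc2/C=C(\C#N)C(=O)Nc2nnc(-c3cccs3)s2)cc1`) gives 40% and compound 2 (`Cc1ccc(S(=O)(=O)Oc2cccc(/C=C(\C#N)C(=O)Nc3nnc(-c4ccccc4)s3)c2)cc1`) gives 52% as its reading. Compound 3 (`COc1ccc(-c2nnc(NC(=O)/C(C#N)=C/c3cccc(OS(=O)(=O)c4ccc(C)cc4)c3)s2)cc1`) has no single number and is reported only as "not toxic" (no number reported) without a figure to compare.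

Compound 4 (`COc1ccccc1-c1nnc(NC(=O)/C(C#N)=C/c2cccc(OS(=O)(=O)c3ccc(C)cc3)c2)s1`) is built from the same atoms, joined differently. Put simply, 2-methoxyphenyl takes the place of 4-methoxyphenyl, and the count of that change reads 2-methoxyphenyl in place of 4-methoxyphenyl on an aromatic carbon on the shared core.

Within the data shown here, no measured step of this kind exists, so the size of the change remains uncertain. A small upward step in this assay or none beyond the scatter is expected, since compound 3 is reported as "not toxic" (no number reported) and that suggests a low starting point. For compound 4 the estimated value is 25% with an expected range of 5% to 50% as the likely span.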

Compound 4, percent growth inhibition at one concentration: "not toxic" (no number reported)
The entry for compound 4 holds no number; the estimate stays without a comparison.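

In this assay compound 3 gives "not toxic" (no number reported) and compound 4 gives "not toxic" (no number reported) without a figure, so no step can be read between them. Going by these compounds, how far 2-methoxyphenyl and 4-methoxyphenyl differ in growth inhibition stays open. No measured evidence bears on these two results.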